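Replacing the amino-alcohol side chain: cytotoxicity outlook

This account rests on a few compounds, and the source may have more. Where it says the series, first, only, none or still open, it means among the compounds named here.

Compound 1: `Cc1c(Cc2ccccc2)c(=O)oc2cc(OCC(O)CNCC3CC3)ccc12` — > 100000 nM
Compound 2: `Cc1c(Cc2ccccc2)c(=O)oc2cc(OCC(O)CNC3CCOCC3)ccc12` — 38200 nM

In an ADME assay on A549 cells (Homo sapiens) for cytotoxicity, read by CellTiter-Glo (a lower number here means that less compound is tolerated, a higher number that more compound is tolerated), compound 1 gives > 100000 nM, which is a limit of the assay rather than a number. Among the measured compounds shown here, compound 2 gives 38200 nM, the only numerical value among the two, so its standing rests on a single point. For the measured compounds named here, the one measured step, an at least 2.6-fold lower number from compound 1 to compound 2 (0.41 log units; beyond the scatter), is itself bounded by a limit (the limit of > 100000 nM in this assay, at which 1 of the 2 values shown sits), so its true size is not fully known. Compound 3, `Cc1c(Cc2ccccc2)c(=O)oc2cc(OCCCNc3nccs3)ccc12`, is not yet measured; it differs from compound 2 by 2-((1,3-thiazol-2-yl)amino)ethyl in place of 1-hydroxy-2-((oxan-4-yl)amino)ethyl on a saturated chain carbon bound to an oxygen on an aromatic ring. The measured step bears only loosely on this change, since it swapped the group on the amine nitrogen, whereas here the whole side chain is exchanged, hydroxyl and amine included. The expectation for compound 3 is a step of a 1.3-fold lower number from compound 2 to compound 3 (0.10 log units; within the scatter), small and uncertain in direction, possibly within the scatter. Compound 3 is estimated at 30000 nM, with a range from 8000 nM to 100000 nM.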

Compound 3, half-maximal cytotoxic concentration: 50100 nM
Compound 3: the middle estimate sits 1.7-fold (0.22 log units) below what was measured; the measured number falls inside the stated range.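

In this assay, the exchange of 1-hydroxy-2-((oxan-4-yl)amino)ethyl for 2-((1,3-thiazol-2-yl)amino)ethyl gives a 1.3-fold higher number from compound 2 to compound 3 (0.12 log units; within the scatter). Among the compounds shown here, this is the first sign that a change this large, which swaps a non-aromatic ring for an aromatic one and removes the hydroxyl, need not move the number beyond the scatter. The other new step, an at least 1.9-fold lower number from compound 1 to compound 3 (0.30 log units; that floor lies within the scatter), ends on a limit of the assay, so its true size is unknown and its floor does not clear the scatter: the limit of > 100000 nM in this assay, at which 1 of the 3 values shown sits.

The compounds shown do not separate the effect of the hydroxyl from that of the ring, which a chain keeping the hydroxyl together with the thiazole would address. On these data alone, how a morpholine or a carboxylic acid at the end of the chain would read also stays open.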